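From 4-acetylphenyl to 4-iodophenyl: what to expect

The source may hold more compounds than are shown below. What is called first, only, known or untested is meant among the compounds shown, and "the series" means these compounds.

In an ADME assay on L929 cells (Mus musculus) for cytotoxicity, read by MTT assay, with a stated time of 72 h (on this read-out lower numbers stand for stronger inhibition and higher numbers for weaker inhibition), compound 1 `Cc1ccc(S(=O)(=O)n2cc(COC3=C/C(=N\c4ccccc4)c4ccccc4C3=O)nn2)cc1` gives > 20000 nM, which is a limit of the assay and not a number. Among the compounds with values here, compound 2 `CC(=O)c1ccc(/N=C2\C=C(OCc3cn(S(=O)(=O)c4ccc(C)cc4)nn3)C(=O)c3ccccc32)cc1` gives 10800 nM, the only true number so far in this assay. Compound 3 `Cc1ccc(S(=O)(=O)n2cc(COC3=C/C(=N\c4ccc(I)cc4)c4ccccc4C3=O)nn2)cc1` differs from compound 2 by iodo in place of acetyl on an aromatic carbon, para to a large group (iodo in place of acetyl on an aromatic carbon). Within the data shown here, one measured step bears on this change: an at least 1.8-fold lower number from compound 1 to compound 2 (0.26 log units; that floor lies within the scatter). It shows what a change at this place has done once, but it says nothing about iodo. Going by these compounds, with only that small floor to go on, no step beyond the scatter is expected in this assay, and the direction stays open. The expected step is a 1.3-fold higher number from compound 2 to compound 3 (0.11 log units; within the scatter). For compound 3 the estimated value is 14000 nM, with an expected range from 6000 nM to 24000 nM.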

Compound 3, half-maximal inhibitory concentration: > 20000 nM
Compound 3: a limit, no number; the forecaster's own chance of this, stated with the estimate: 35%; middle value at least 1.4-fold (0.15 log units) from the limit.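

In this assay compound 3 gives a limit and not a number, so of the three groups tried at this place only acetyl yields a true number. Iodo in place of acetyl gives an at least 1.8-fold higher number from compound 2 to compound 3 (0.26 log units; that floor lies within the scatter) as its only readable step, and because that is a floor, the real gap may be larger but is not shown to exceed the usual scatter. The step from hydrogen to iodo cannot be read, and what can be said at this place is bounded by the top of the assay's range: the limit of > 20000 nM in this assay, at which 2 of the 3 values shown sit.

Going by these compounds, how far compound 1 and compound 3 lie past that limit stays open, and so does whether the true number of compound 2 is particular to acetyl. Whether an amine or a carboxylic acid at this place would also give a true number is likewise unsettled.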